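The source may report more compounds than this note shows. Statements on the series, on what has been measured and on what is new or still open speak of the compounds shown alone.

Of the compounds shown here, two built on the same shared core have been tested in a functional assay on PC-3 cells (Homo sapiens) for inhibition; on this read-out lower numbers stand for stronger inhibition of growth and higher numbers for weaker inhibition of growth. Compound 1, `O=C(COc1ccc(/C=C2\SC(=O)NC2=O)cc1)Nc1ccccc1`, carries a plain phenyl on the amide nitrogen. For compound 1 the assay reports only a limit, > 100000 nM, which is the limit of > 100000 nM in this assay, at which 1 of the 2 values shown sits. Compound 2, `O=C(COc1ccc(/C=C2\SC(=O)NC2=O)cc1)Nc1ccc(Br)cc1`, carries bromo in place of hydrogen on an aromatic carbon, and in this assay compound 2 gives 86600 nM. The step of an at least 1.1-fold lower number from compound 1 to compound 2 (0.06 log units; that floor lies within the scatter) stays within the usual scatter, so these two compounds cannot be told apart on the numbers. Compound 2 therefore holds the only number shown, the other value being a limit.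

Compound 3, `O=C(COc1ccc(/C=C2\SC(=O)NC2=O)cc1)Nc1c(Cl)cccc1Cl`, has not yet been measured. It differs from compound 2 by 2,6-dichlorophenyl in place of 4-bromophenyl on an amide-type nitrogen. For the measured compounds named here, no measured step covers this change: the only step available, an at least 1.1-fold lower number from compound 1 to compound 2 (0.06 log units; that floor lies within the scatter), is within the scatter and concerns bromo in place of hydrogen on an aromatic carbon. On that basis the expected step is a 1.0-fold higher number from compound 2 to compound 3 (0.02 log units; within the scatter), with no movement beyond the scatter. Compound 3 is estimated at 90000 nM, between 30000 nM and 300000 nM, and a limit rather than a number may well be reported.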

Compound 3, concentration for 50% growth inhibition: > 100000 nM
Compound 3 ended at the assay's limit; the forecaster's own chance of this, stated with the estimate: 45%; middle value at least 1.1-fold (0.04 log units) away from the limit.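

Placing 2,6-dichlorophenyl in place of 4-bromophenyl on the amide-type nitrogen gives an at least 1.1-fold higher number from compound 2 to compound 3 (0.06 log units; that floor lies within the scatter), so this larger swap of the aromatic group, like the single bromo before it, yields no step that can be claimed beyond the scatter. The step linking the other pair, compound 1 and compound 3, cannot be read, as two limits leave its size unknown. With a plain phenyl in compound 1, 4-bromophenyl in compound 2 and 2,6-dichlorophenyl in compound 3, the numbers do not tell these three compounds apart, and most of the series rests at the top of the measurable range: the limit of > 100000 nM in this assay, at which 2 of the 3 values shown sit.

As far as these compounds go, what remains open is whether any group on this nitrogen can bring the number clearly down, for example a phenyl ring carrying a methoxy group, an amine or a carboxylic acid, or a longer alkyl chain in place of the ring. Also open, from the compounds shown here alone, is how far compound 2 and compound 3 truly lie apart, since a limit fixes only one side of that gap.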